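An Aromatic Substituent Exchange Set Against a Chain Truncation

A few compounds are considered here, and "the series" means these few. Any claim that something is new, unique, unknown or untested is made for them only; others in the source may bear on it.

Compound 1 `CCCSc1nc(=O)ccn1[C@@H]1O[C@H](COP(=O)(O)OP(=O)(O)O)[C@@H](O)[C@H]1O`: 1200 nM
Compound 2 `CCCSc1nc(=O)ccn1[C@@H]1O[C@H](COP(=O)(O)O)[C@@H](O)[C@H]1O`: 4800 nM

In an in vitro functional assay on 1321-N1 cells for agonist activity at P2Y purinoceptor 2 (Homo sapiens), read by scintillation proximity assay and inositol phosphate accumulation (on this read-out higher numbers stand for an effect only at larger amounts of compound and lower numbers for an effect already at smaller amounts), compound 1 gives 1200 nM, the lowest of the two numbers shown. Its nearest neighbour is compound 2, which in this assay gives 4800 nM; the step of a 4.0-fold higher number from compound 1 to compound 2 (0.60 log units; beyond the scatter) follows from a hydrogen atom in place of a group of 4 heavy atoms on an oxygen.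

Compound 3 `CNc1nc(=O)ccn1[C@@H]1O[C@H](COP(=O)(O)OP(=O)(O)O)[C@@H](O)[C@H]1O` has not been measured. It differs from compound 1 by methylamino in place of propylsulfanyl on an aromatic carbon. Among the measured compounds shown here, the only measured step, a 4.0-fold higher number from compound 1 to compound 2 (0.60 log units; beyond the scatter), concerns an oxygen of the chain and not the aromatic carbon, so no measured step bears on this exchange. With nothing to anchor a direction, compound 3 is expected to stay close to compound 1, with a step of no change at the digits printed from compound 1 to compound 3 (within the scatter) that need not exceed the scatter. The estimate for compound 3 in this assay is 1200 nM, within 250 nM to 6000 nM.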

Compound 3, half-maximal effective concentration: 7600 nM
The estimate for compound 3 lay 6.3-fold (0.80 log units) below the measured number; measured number above the stated range.
By their numbers in this assay, from the lowest: compound 1; then compounds 2 and 3 (each within the scatter of the next).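

The aromatic carbon between two ring nitrogen atoms proves sensitive to its substituent: in this assay, methylamino in place of propylsulfanyl gives a 6.3-fold higher number from compound 1 to compound 3 (0.80 log units; beyond the scatter). Among the compounds shown here, this is the first measured change at this carbon, as the earlier step concerned only the chain on the oxygen, and it shows that the propylsulfanyl compound holds the lower number with the diphosphate chain kept the same. For the compounds shown here, the exchange alters the linking atom and the chain together, so the single step cannot assign the change to either one. No supporting evidence explains this change.

The compounds shown leave open whether a methylsulfanyl or a longer alkylsulfanyl chain, or a propylamino group, would separate these two contributions. They also leave open how removing the terminal phosphate would act on a methylamino compound.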